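The source may report more compounds than this note shows. Statements on the series, on what has been measured and on what is new or still open speak of the compounds shown alone.

Compound 1 `O=C(CCCCCc1ccccc1)c1nc2cccc(Br)c2o1` and compound 2 `O=C(CCCCCCc1ccccc1)c1nc(C(=O)C(F)(F)F)co1` were both tested in an assay on HEK-293T cells for inhibition of diacylglycerol lipase-alpha (Homo sapiens), read by colorimetric assay; on this read-out lower numbers stand for stronger inhibition and higher numbers for weaker inhibition. For compound 1 the result is only a limit of the assay, > 10000 nM. Compound 1 thus sits at the limit of > 10000 nM in this assay, at which 1 of the 2 values shown sits. Compound 2 gives 123 nM in this assay, the only number among the results shown. Compound 3 `CS(=O)(=O)c1coc(C(=O)CCCCCCc2ccccc2)n1` has not yet been measured and differs from compound 2 by methylsulfonyl in place of (trifluoromethyl)carbonyl on an aromatic carbon. Among the measured compounds shown here, no measured pair shows this change. The step in this assay is expected to be a 41-fold higher number from compound 2 to compound 3 (1.61 log units; beyond the scatter), toward weaker inhibition. Compound 3 is therefore expected to give about 5000 nM, somewhere between 800 nM and 30000 nM.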

Compound 3, half-maximal inhibitory concentration: 389 nM
Estimate against measurement, compound 3: 13-fold (1.11 log units) above; the whole stated range lies above it.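

In this assay, putting methylsulfonyl in place of (trifluoromethyl)carbonyl on this aromatic carbon gives a 3.2-fold higher number from compound 2 to compound 3 (0.50 log units; beyond the scatter), a modest loss of inhibition. Inhibition therefore does not depend on (trifluoromethyl)carbonyl alone: with a group that has no fluorine and no carbonyl at this position, compound 3 still gives 389 nM. Nothing measured here explains the size of this step.

Still open, going by these compounds, is how a nitrile, a carboxylic acid or an amine on this carbon would compare. A plain hydrogen there would show how much any such group contributes to inhibition.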